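Branching the alkyl arm of a cyanoguanidine blood-pressure lowerer

The compounds below may be only part of what the source reports. "The series", "measured", "known", "first", "only" and "open" are said of these compounds alone.

Measured so far:
compound 1 `CC(C)C(C)(C)/N=C(\NC#N)Nc1cccnc1` gives 1 mg/kg in a functional assay on the whole organism (blood, strain Wistar-Okamoto) with Rattus norvegicus as the target, with a stated time of 5 days; on this read-out lower numbers stand for an effect already at smaller amounts and higher numbers for an effect only at larger amounts of compound
compound 2 `CCC(CC)/N=C(\NC#N)Nc1ccncc1` gives 2.5 mg/kg in this assay
compound 3 `N#CN/C(=N\C1CCCCCCC1)Nc1ccncc1` reaches only the limit > 20 mg/kg in this assay; this is a limit of the assay, not a number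

Among the two compounds with a measured number, compound 2 stands highest; its nearest neighbour is compound 1, whose number is lower by a margin beyond the usual scatter, so compound 1 acts at a smaller dose. Compound 3 sits at the limit (the limit of > 20 mg/kg in this assay, at which 1 of the 3 values shown sits).

Compound 4 `CCC(C)(CC)/N=C(\NC#N)Nc1ccncc1` has not yet been measured. It differs from compound 2 in one place: methyl in place of hydrogen on a saturated chain carbon bound to a double-bonded nitrogen and two saturated chain carbons. Since no measured pair shows this change, its effect can only be guessed from the numbers shown. Compound 1, which also carries a fully substituted chain carbon next to the double-bonded nitrogen, gives 1 mg/kg, so a modest move toward a lower dose is expected from compound 2 to compound 4: a 1.7-fold lower number from compound 2 to compound 4 (0.22 log units; within the scatter). For compound 4 the expected value is 1.5 mg/kg, with a range from 0.5 mg/kg to 5 mg/kg.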

Compound 4, minimum effective dose: 0.5 mg/kg
Beside the measured number, compound 4's estimate is 3.0-fold (0.48 log units) above it; the measured number falls inside the stated range.
By their numbers in this assay, from the lowest: compounds 4 and 1 (each within the scatter of the next); then compound 2. At a limit, above all of these: compound 3.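

Among these compounds, replacing hydrogen with methyl on a saturated chain carbon bound to a double-bonded nitrogen and two saturated chain carbons, which turns pentan-3-yl into 1-ethyl-1-methylpropyl, gives a 5.0-fold lower number from compound 2 to compound 4 (0.70 log units; beyond the scatter) in this assay, and this is the first measured pair that differs in one place. It shows directly that this chain carbon does not need its hydrogen for the effect to remain, and that one added carbon atom can shift the effective dose by more than the usual scatter. The numbers shown give no reason for this step.

On these data alone, it remains open whether an ethyl, a hydroxyl or an amine on this same carbon would lower or raise the dose further. A single pair also cannot tell whether methyl gives a similar step on a longer chain, such as one with propyl arms.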